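This account rests on a few compounds, and the source may have more. Where it says the series, first, only, none or still open, it means among the compounds named here.

Compound 1 `Cn1cccc1-c1cc(-c2cccs2)nc(N)c1C#N`: > 100000 nM
Compound 2 `Cn1cccc1-c1cc(-c2cccs2)[nH]c(=O)c1C#N`: 83200 nM
Compound 3 `Cn1cccc1-c1cc(-c2ccccc2)[nH]c(=O)c1C#N`: > 100000 nM

All three were tested in a functional assay on HOP-62 cells (Homo sapiens) for inhibition, read by sulforhodamine B assay, with a stated time of 48 h; on this read-out higher numbers stand for weaker inhibition of growth and lower numbers for stronger inhibition of growth. In this assay compound 2 gives 83200 nM. For compound 1 the value > 100000 nM is a limit of the assay, not a number. For compound 3 the value > 100000 nM is likewise a limit. The step of an at least 1.2-fold higher number from compound 2 to compound 3 (0.07 log units; that floor lies within the scatter) is phenyl in place of thiophen-2-yl on an aromatic carbon. The difference between the cores of compound 1 and compound 2 is not broken down here. Compound 4 `Cn1cccc1-c1cc(-c2ccccc2)nc(N)c1C#N` is unmeasured and differs from compound 1 by phenyl in place of thiophen-2-yl on an aromatic carbon, the same kind of change, the place differing in that the group of 1 heavy atom is an amino group. Because compound 1 sits at the limit of > 100000 nM in this assay, at which 2 of the 3 values shown sit, and the measured step of an at least 1.2-fold higher number from compound 2 to compound 3 (0.07 log units; that floor lies within the scatter) is small, compound 4 is expected near 150000 nM, between 90000 nM and 300000 nM. For compound 4 the expected step is a step that the limit leaves unreadable from compound 1 to compound 4, most likely reported only as a limit.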

Compound 4, concentration for 50% growth inhibition: 81300 nM
For compound 4 the middle estimate is 1.8-fold (0.27 log units) above the measured one, and the stated range ends above it.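

In this assay, phenyl in place of thiophen-2-yl on an aromatic carbon gives an at least 1.2-fold lower number from compound 1 to compound 4 (0.08 log units; that floor lies within the scatter). Set beside the same change on the other core, the comparison reads: the same change on two cores in this assay, an at least 1.2-fold higher number (0.07 log units; that floor lies within the scatter) from compound 2 to compound 3 and an at least 1.2-fold lower number (0.08 log units; that floor lies within the scatter) from compound 1 to compound 4; the limit leaves it open whether they differ. The two steps therefore show neither that the change carries over from one core to the other nor that it behaves differently on each, because their true sizes remain hidden: the limit of > 100000 nM in this assay, at which 2 of the 4 values shown sit.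

The compounds shown leave open what an amine or a carboxylic acid on the phenyl ring would do in this assay. They also leave open whether replacing the 1-methyl-1H-pyrrol-2-yl group with a longer chain would change the result on either core.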